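Notes on the aryl urea end of the series

The source may hold more compounds than are shown below. What is called first, only, known or untested is meant among the compounds shown, and "the series" means these compounds.

Measured so far in an assay on CHO cells for antagonist activity at transient receptor potential cation channel subfamily V member 1 (Homo sapiens), read by scintillation counting, with a stated time of 5 min, in the presence of a further agent that is not named here; on this read-out lower numbers stand for an effect already at smaller amounts and higher numbers for an effect only at larger amounts of compound:
Compound 1, `CN(C)C1(Cc2ccccc2)CCN(c2cc(C(F)(F)F)ccc2CNC(=O)Nc2cccc3c2CC(O)CC3)CC1`, gives 10.1 nM.
Compound 2, `CN(C)C1(Cc2ccccc2)CCN(c2cc(C(F)(F)F)ccc2CNC(=O)Nc2cccc3[nH]c(=O)ccc23)CC1`, gives 30.6 nM.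
Compound 3, `CN(C)C1(Cc2ccccc2)CCN(c2cc(C(F)(F)F)ccc2CNC(=O)Nc2ccc3cccnc3c2)CC1`, gives 42 nM.

Compound 3 holds the highest of the three numbers in this assay. Against compound 2 the gap is small: a 1.4-fold higher number from compound 2 to compound 3 (0.14 log units; within the scatter). Against compound 1 it is clearer: a 4.2-fold higher number from compound 1 to compound 3 (0.62 log units; beyond the scatter).

Compound 4, `CN(C)C1(Cc2ccccc2)CCN(c2cc(C(F)(F)F)ccc2CNC(=O)Nc2cccc3cnccc23)CC1`, is not yet measured. It differs from compound 3 in one place: isoquinolin-5-yl in place of quinolin-7-yl on an amide-type nitrogen. The two have the same atoms, joined differently.

Among the measured compounds shown here, three measured steps touch the same position on the urea. Replacing the saturated, hydroxyl-bearing ring system of compound 1 by an aromatic bicycle gave a 3.0-fold higher number from compound 1 to compound 2 (0.48 log units; beyond the scatter) and a 4.2-fold higher number from compound 1 to compound 3 (0.62 log units; beyond the scatter). Exchanging one aromatic bicycle for another gave only a 1.4-fold higher number from compound 2 to compound 3 (0.14 log units; within the scatter). The step from compound 3 to compound 4 is of this last kind, an aromatic bicycle for an aromatic bicycle, so no step beyond the scatter is expected in this assay, with the number kept near that of compound 3.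

Compound 4 is therefore expected at 40 nM, within a range of 15 nM to 120 nM, the step being a 1.1-fold lower number from compound 3 to compound 4 (0.02 log units; within the scatter).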

Compound 4, half-maximal effective concentration: 8.8 nM
Compound 4: middle estimate off by 4.5-fold (0.66 log units), on the high side, outside the stated range (below it).
By their numbers in this assay, from the lowest: compounds 4 and 1 (each within the scatter of the next); then compounds 2 and 3 (each within the scatter of the next).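

In this assay this position on the amide-type nitrogen proves sensitive to how the same atoms are joined: isoquinolin-5-yl in place of quinolin-7-yl gives a 4.8-fold lower number from compound 3 to compound 4 (0.68 log units; beyond the scatter) and so, unlike the exchange between compound 2 and compound 3, this swap of one aromatic bicycle for another is not neutral. The isoquinolin-5-yl group also separates from the bicycle of compound 2 (a step of a 3.5-fold lower number from compound 2 to compound 4 (0.54 log units; beyond the scatter)), while the step of a 1.1-fold lower number from compound 1 to compound 4 (0.06 log units; within the scatter) leaves no separation from 3-hydroxy-1,2,3,4-tetrahydronaphthalen-5-yl, so the higher numbers seen on leaving compound 1 hold for compound 2 and compound 3 but go against compound 4. Nothing at hand accounts for the difference between the two isomers.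

The compounds shown leave open whether the step follows the attachment point or the place of the ring nitrogen, a question that quinolin-5-yl at the same position would help to separate. They also leave open whether a ring nitrogen is needed at all, which naphthalen-1-yl, with carbon only in both rings, would address.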